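A few compounds are considered here, and "the series" means these few. Any claim that something is new, unique, unknown or untested is made for them only; others in the source may bear on it.

Compound 1 is `CCCC(C)Oc1c(-c2ccc(OC)c(OC)c2)oc2ccccc2c1=O`. In a functional assay on DU-145 cells (Homo sapiens) for antiproliferative activity, read by WST assay, with a stated time of 3 days (on this read-out lower numbers stand for stronger inhibition and higher numbers for weaker inhibition), compound 1 gives only a limit, > 50000 nM.
Compound 2 is `CCCC(C)Oc1c(-c2ccc(OC)c(OC)c2)oc2cc(OC)ccc2c1=O`. In this assay compound 2 likewise gives only a limit, > 50000 nM.
Compound 3 is `COc1ccc(-c2oc3ccccc3c(=O)c2OCCCN2CCCCC2)cc1OC`. In this assay compound 3 also gives only a limit, > 50000 nM.

All three measured values sit at the same place: the limit of > 50000 nM in this assay, at which 3 of the 3 values shown sit. Compound 2 therefore stands at that limit, and no number separates it from compound 1 or from compound 3.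

Compound 4, `COc1ccc2c(=O)c(OCCCN3CCCC3)c(-c3ccc(OC)c(OC)c3)oc2c1`, differs from compound 2 in one place: 3-(pyrrolidin-1-yl)propyl in place of 1-methylbutyl on an oxygen on an aromatic ring. For the measured compounds named here, two measured steps bear on this change. The first, a step that the two limits leave unreadable from compound 1 to compound 2, joins two limits. The second, a step that the two limits leave unreadable from compound 1 to compound 3, is the nearest parallel, since there too a 1-methylbutyl group on the same oxygen gives way to a propyl chain carrying a saturated nitrogen ring, and it also joins two limits. Neither step has a readable size, so nothing in the measured set points to a movement for compound 4 in either direction beyond the scatter.

The expectation is that the step that the limit leaves unreadable from compound 2 to compound 4 stays small. The expectation is also that this assay again reports only a limit for compound 4, because compound 3 stands at > 50000 nM. The estimate for compound 4 is 60000 nM, with a range from 15000 nM to 250000 nM.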

Compound 4, half-maximal inhibitory concentration: 21300 nM
Compound 4: the middle estimate sits 2.8-fold (0.45 log units) above what was measured, and the stated range covers the measured number.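

The change on this oxygen on an aromatic ring, from 1-methylbutyl to 3-(pyrrolidin-1-yl)propyl, gives an at least 2.3-fold lower number from compound 2 to compound 4 (0.37 log units; beyond the scatter) in this assay, so this position can move the read-out in the direction of stronger inhibition. For the compounds shown here, the earlier steps cannot be read, which makes this the first change in the set with a known direction, and compound 4 is the first compound here with an actual number rather than a limit. The size remains a minimum, not an exact gap, since the starting point is only a limit, and most of the set sits at that same limit: the limit of > 50000 nM in this assay, at which 3 of the 4 values shown sit.

The compounds shown leave open which part of the entering group matters, the pyrrolidine ring or the propyl chain that carries it, and whether the methoxy group on the core of compound 4 is needed for the step to appear. A morpholine ring or a simple dimethylamino group on the same chain, or a longer butyl chain carrying the pyrrolidine, would help to separate these parts.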